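Mirroring a Single Stereocentre in Compound 2

The source may report more compounds than this note shows. Statements on the series, on what has been measured and on what is new or still open speak of the compounds shown alone.

Of the compounds shown here, two have been measured in a functional assay on B16-F10 cells (Mus musculus) for antiproliferative activity, read by MTT assay, with a stated time of 48 h; a higher number here means a weaker inhibitor, a lower number a stronger inhibitor. Compound 1 `O=C(/C=C/[C@H](O)Cc1ccccc1)CCc1ccccc1` gives 130000 nM. Compound 2 `COc1ccc(CCC(=O)/C=C/[C@H](O)Cc2ccccc2)cc1OC` gives 38200 nM, the lower of the two numbers; its nearest neighbour is compound 1, and the gap between them lies beyond the usual scatter of repeated measurements.

Compound 3 `COc1ccc(CCC(=O)/C=C/[C@@H](O)Cc2ccccc2)cc1OC` has not yet been measured. It differs from compound 2 as follows: the two compounds have the same atoms and bonds and differ only in configuration as drawn: 1 of 2 stereo elements differ; a stereocentre at a saturated chain carbon is drawn R in compound 2 and S in compound 3. Within the data shown here, no step between two measured compounds shows what such a change of configuration does here, so the expectation rests on compound 2 alone. Because compound 2 gives 38200 nM and nothing shows which drawn configuration is favoured, compound 3 is expected to land near that number, perhaps somewhat higher, with wide uncertainty. The estimated value for compound 3 in this assay is 55000 nM, within a range from 18000 nM to 170000 nM. The expected step is a 1.4-fold higher number from compound 2 to compound 3 (0.16 log units; within the scatter), a modest weakening that may well fall inside the scatter.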

Compound 3, half-maximal inhibitory concentration: 96900 nM
Compound 3: the middle estimate sits 1.8-fold (0.25 log units) below what was measured, and the stated range covers the measured number.
By their numbers in this assay, from the lowest: compound 2; then compounds 3 and 1 (each within the scatter of the next).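

Drawing the stereocentre at the saturated chain carbon as S rather than R gives a 2.5-fold higher number from compound 2 to compound 3 (0.40 log units; beyond the scatter) in this assay, so this position responds to configuration and the R form of compound 2 is the favoured one of this pair. Among these compounds, the step is modest, yet it is the first sign that the three-dimensional arrangement at this carbon matters, and not only which groups are present. It can be laid to that single stereocentre alone, because of one fact: the fact that compounds 2 and 3 differ only in the configuration as drawn

Among the compounds shown here, whether the same preference holds on the core of compound 1 remains open, since only one such pair can be read. Also open, going by these compounds, is whether an amine in place of the hydroxyl would keep any preference between the two configurations, and the reason for the preference cannot be read from these numbers.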